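The source may hold more compounds than are shown below. What is called first, only, known or untested is meant among the compounds shown, and "the series" means these compounds.

Compound 3 `COc1ccc(CNC(=O)CSc2nc3ccc(NC(=O)CCl)cc3s2)cc1` gives 5100 nM in a functional assay on MCF7 cells (Homo sapiens) for cytotoxicity, read by MTT assay, with a stated time of 48 h (a lower number here means a stronger inhibitor, a higher number a weaker inhibitor), the lowest of the two numbers at hand. Compound 2 `O=C(CSc1nc2ccc(NC(=O)c3ccc(Cl)cc3)cc2s1)NCc1ccc(Cl)cc1` gives 29300 nM. Compound 1 `COc1ccc(CNC(=O)CSc2nc3ccc(NC(=O)c4ccc([N+](=O)[O-])cc4)cc3s2)cc1` reports only a limit, > 100000 nM, as noted in the limit of > 100000 nM in this assay, at which 1 of the 3 values shown sits. Compound 4 `COc1ccc(CNC(=O)CSc2nc3ccc(NC(=O)c4ccc(Cl)cc4)cc3s2)cc1` differs from compound 3 in one place: 4-chlorophenyl in place of chloromethyl on a carbonyl carbon. Among the measured compounds shown here, the one step that bears on this change runs in the opposite direction, an at least 19-fold lower number from compound 1 to compound 3 (1.29 log units; beyond the scatter), where removing the ring group brought a large drop in the number. Putting a ring group back is therefore expected to raise the number by a large step, a 5.9-fold higher number from compound 3 to compound 4 (0.77 log units; beyond the scatter), in keeping with compound 2, which also carries 4-chlorophenyl. Compound 4 is estimated at 30000 nM, between 8000 nM and 100000 nM.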

Compound 4, half-maximal inhibitory concentration: 19200 nM
Compound 4: the middle estimate sits 1.6-fold (0.19 log units) above what was measured; low and high end bracket the measured number.
By their numbers in this assay, from the lowest: compound 3; then compounds 4 and 2 (each within the scatter of the next). At a limit, above all of these: compound 1.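

With a ring on this carbonyl carbon, the step away from chloromethyl now has a real size rather than one resting only on a limit: a 3.8-fold higher number from compound 3 to compound 4 (0.58 log units; beyond the scatter). On that ring, chloro in place of nitro gives an at least 5.2-fold lower number from compound 1 to compound 4 (0.71 log units; beyond the scatter), a step that still rests on a limit of the assay for compound 1. Methoxy in place of chloro on an aromatic carbon stays within the scatter, a 1.5-fold lower number from compound 2 to compound 4 (0.18 log units; within the scatter).

Open, as far as these compounds go, is whether the chlorine of chloromethyl matters, or whether a plain methyl or a longer chain on this carbonyl carbon would give a number as low as that of compound 3.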